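The source may hold more compounds than are shown below. What is called first, only, known or untested is meant among the compounds shown, and "the series" means these compounds.

Values in a functional assay on MOLT-4 cells (Homo sapiens) for inhibition, read by MTT assay, with a stated time of 72 h; a higher number here means a weaker inhibitor, a lower number a stronger inhibitor:
- Compound 1 `COc1cc(NC(C)CCCNC(=O)Nc2ccc(Br)cc2)c2ncccc2c1`: 25000 nM
- Compound 2 `COc1cc(NC(C)CCCNC(=O)NNC(=O)Nc2ccc(F)cc2)c2ncccc2c1`: >= 250000 nM
- Compound 3 `COc1cc(NC(C)CCCNC(=O)NNC(=O)Nc2ccc(Cl)cc2)c2ncccc2c1`: 186000 nM

The entry for compound 2, >= 250000 nM, is a limit of the assay and not a number. Compound 3 stands highest of the two values given as numbers, and the measured step up to it is a 7.4-fold higher number from compound 1 to compound 3 (0.87 log units; beyond the scatter).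

Compound 4 `COc1cc(NC(C)CCCNC(=O)Nc2ccc(F)cc2)c2ncccc2c1` has not yet been measured. It replaces ((4-chlorophenyl)carbamoyl)amino with 4-fluorophenyl on an amide-type nitrogen: 4-fluorophenyl in place of ((4-chlorophenyl)carbamoyl)amino on an amide-type nitrogen. This largely reverses the change already seen in a 7.4-fold higher number from compound 1 to compound 3 (0.87 log units; beyond the scatter) and in an at least 10-fold higher number from compound 1 to compound 2 (1.00 log units; beyond the scatter), while the halogen swap alone shows only an at least 1.3-fold lower number from compound 2 to compound 3 (0.12 log units; that floor lies within the scatter). Compound 4 shares its shorter side chain with compound 1, which gives 25000 nM, so a lower number is expected in this assay. The expected change is a 5.8-fold lower number from compound 3 to compound 4 (0.76 log units; beyond the scatter), a step beyond the scatter. Compound 4 is estimated at 32000 nM, with an expected range of 13000 nM to 80000 nM.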

Compound 4, half-maximal inhibitory concentration: 24000 nM
The estimate for compound 4 lay 1.3-fold (0.12 log units) above the measured number, within the range that was stated.
By their numbers in this assay, from the lowest: compounds 4 and 1 (each within the scatter of the next); then compound 3. At a limit, above all of these: compound 2.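

In this assay, 4-fluorophenyl on the amide-type nitrogen in place of the larger group gives a 7.8-fold lower number from compound 3 to compound 4 (0.89 log units; beyond the scatter), and with the fluoro held constant, the same exchange gives an at least 10-fold lower number from compound 2 to compound 4 (1.01 log units; beyond the scatter). That second step is only a floor, since compound 2 stands at a limit of the assay and not at a number: the limit of >= 250000 nM in this assay, at which 1 of the 4 values shown sits. The halogen on the aromatic carbon makes no difference that can be read between the two compounds lacking the carbamoylamino unit, with a 1.0-fold lower number from compound 1 to compound 4 (0.02 log units; within the scatter), so among these compounds, the higher numbers go with that unit and not with the change of halogen.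

The compounds shown leave open which part of the unit matters, the added nitrogen or the added carbonyl. They also do not tell how a 4-methoxyphenyl or a 4-carboxyphenyl group would read on this nitrogen.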